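The compounds below may be only part of what the source reports. "The series", "measured", "known", "first", "only" and "open" are said of these compounds alone.

Compound 1 `O=S(=O)(NCc1cc2ccccc2s1)c1ccc(Cl)cc1` and compound 2 `O=S(=O)(NCc1cc2ccccc2s1)c1ccc(Br)cc1` share one core and differ only in the group on the six-membered aromatic ring of carbon only. In an ADME assay on MDCK cells (Canis lupus familiaris) for cytotoxicity, read by MTT assay, with a stated time of 24 h (on this read-out higher numbers stand for lower toxicity in this test and lower numbers for higher toxicity in this test), compound 1 gives "not determined" (no result reported). In this assay compound 2 gives > 174000 nM, and this is a limit of the assay rather than a number. Among the two entries shown, compound 2 thus sits at the limit of > 174000 nM in this assay, at which 1 of the 2 values shown sits, while the other entry carries no single number at all. Compound 3 `O=S(=O)(NCc1cc2ccccc2s1)c1ccc(C(F)(F)F)cc1` arises from compound 2 by the change (trifluoromethyl in place of bromo on an aromatic carbon). For the measured compounds named here, no step between two measured compounds is available, so no measured size of effect guides the expectation. The step that the limit leaves unreadable from compound 2 to compound 3 is expected to stay within the usual scatter. Compound 3 is therefore expected to give 200000 nM in this assay, with a range from 90000 nM to 450000 nM, and it may well be reported again only as a limit.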

Compound 3, half-maximal cytotoxic concentration: > 179000 nM
Compound 3 was reported as a limit; the forecaster's own chance of this, stated with the estimate: 75%; the middle value does not contradict the limit.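

Compound 2 and compound 3 are both reported only as limits in this assay, so the step between them cannot be read. The compounds shown leave open at what concentration, if any, compound 2 and compound 3 turn cytotoxic, and whether the two differ at all.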